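This account rests on a few compounds, and the source may have more. Where it says the series, first, only, none or still open, it means among the compounds named here.

Measured so far:
compound 1 `CCCCOC(=O)OCC1OC(n2cc(C)c(=O)[nH]c2=O)CC1N=[N+]=[N-]` — 0.15 h
compound 2 `Cc1cn(C2CC(N=[N+]=[N-])C(COC(=O)OCCO)O2)c(=O)[nH]c1=O` — < 0.0167 h

In an ADME assay on the whole organism (serum) with Homo sapiens as the target (a lower number here means that the compound disappears faster, a higher number that the compound lasts longer), compound 1 gives 0.15 h. For compound 2 the reading is a limit of the assay, < 0.0167 h, as the limit of < 0.0167 h in this assay, at which 1 of the 2 values shown sits, records. Compound 2 thus sits at the bottom of the numbers shown, with only a ceiling known for it. Going by the values given here, the single measured step, an at least 8.9-fold lower number from compound 1 to compound 2 (0.95 log units; beyond the scatter), is the one that brought in the hydroxy now present in compound 2. Compound 3 `Cc1cn(C2CC(N=[N+]=[N-])C(COC(=O)OCCCO)O2)c(=O)[nH]c1=O` differs from compound 2 by hydroxymethyl in place of hydroxy on a saturated chain carbon, two bonds along the chain from an oxygen next to a carbonyl group. Among the compounds with values here, no measured step tracks this kind of chain lengthening at this position; the measured step concerns the arrival of the hydroxy itself, not its distance along the chain. Compound 3 is expected to remain very short-lived, with an at least 1.1-fold higher number from compound 2 to compound 3 (0.07 log units; that floor lies within the scatter) the estimated step. The estimate for compound 3 in this assay is 0.02 h, in the range 0.008 h to 0.06 h.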

Compound 3, half-life: 0.167 h
Estimate against measurement, compound 3: 8.4-fold (0.92 log units) below; the measured number lies above the stated range.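

In this assay, 2-hydroxyethoxy to 3-hydroxypropoxy gives an at least 10-fold higher number from compound 2 to compound 3 (1.00 log units; beyond the scatter), so at this position the short half-life of compound 2 does not follow from the presence of a hydroxy alone; chain length matters as well. Hydroxy in place of methyl on a saturated chain carbon, three bonds along the chain from an oxygen next to a carbonyl group, gives a 1.1-fold higher number from compound 1 to compound 3 (0.05 log units; within the scatter), which leaves the two compounds level in this assay. For compound 2 only a limit of the assay is known, so the first step gives a floor and not a size: the limit of < 0.0167 h in this assay, at which 1 of the 3 values shown sits.

Still open, from the compounds shown here alone, is whether a longer chain, such as 4-hydroxybutoxy, holds the half-life at the level of compound 3. The compounds shown also do not say how an amine or a carboxylic acid in place of the hydroxy would behave on the three-carbon chain.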